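Working notes: chloro in place of amino, compound 4

The compounds below may be only part of what the source reports. "The series", "measured", "known", "first", "only" and "open" are said of these compounds alone.

Results so far in a functional assay on KB cells (Homo sapiens) for cytotoxicity, read by MTT assay, with a stated time of 72 h (a lower number here means a stronger inhibitor, a higher number a weaker inhibitor), are as follows.
- compound 1 `COc1ccc(Nc2nc3ccccc3nc2S(=O)(=O)c2ccc(OC)cc2)cc1` reads "not determined" (no result reported)
- compound 2 `COc1ccc(S(=O)(=O)c2nc3ccccc3nc2Nc2cc(OC)cc(OC)c2)cc1` reads "not determined" (no result reported)
- compound 3 `COc1ccc(S(=O)(=O)c2nc3ccccc3nc2Nc2ccc(N)cc2)cc1` reads 17800 nM

Among the compounds with values here, compound 3 carries the only number. Within the data shown here, compound 1 and compound 2 have no result, so compound 3 cannot be ranked against anything yet, and the series offers no measured step between compounds.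

Compound 4 `COc1ccc(S(=O)(=O)c2nc3ccccc3nc2Nc2ccc(Cl)cc2)cc1` keeps the shared core and changes one group: chloro in place of amino on an aromatic carbon. This puts chloro in place of amino on an aromatic carbon, para to a large group. Among the measured compounds shown here, no measured pair shows what this change does in this assay, so the expectation is cautious and the range wide. For the measured compounds named here, the only anchor is compound 3 at 17800 nM. Going by the values given here, a slight move toward a lower number is expected, with no step clearly beyond the scatter.

The estimated change is a 1.5-fold lower number from compound 3 to compound 4 (0.17 log units; within the scatter).

For compound 4 the expected value is 12000 nM, with an estimated range from 3000 nM to 40000 nM.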

Compound 4, half-maximal inhibitory concentration: 49800 nM
Compound 4: the middle estimate sits 4.2-fold (0.62 log units) below what was measured, and the stated range ends below it.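

Notes on compound 4: in this assay, the aromatic carbon para to a large group now has its first measured step, where chloro in place of amino gives a 2.8-fold higher number from compound 3 to compound 4 (0.45 log units; beyond the scatter) and places compound 3 as the stronger of this pair. The group at this position therefore changes the read-out by more than the usual scatter, although this rests on a single pair. No measured evidence bears on why the number rises.

One pair cannot separate the loss of amino from the gain of chloro, and steps involving compound 1 or compound 2 cannot be read. On these data alone, whether a hydroxyl, a methyl or a dimethylamino group at the same place would read nearer compound 3 or compound 4 remains open.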